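Series notes: carbamoyl to benzyloxycarbonyl, compound 1 to compound 4

This account rests on a few compounds, and the source may have more. Where it says the series, first, only, none or still open, it means among the compounds named here.

Measured so far, all in a functional assay on the whole organism (Tail, strain ICR) with Mus musculus as the target, in the tail flick test, with a stated time of 60 min, at a dose of 25 umol/kg by the oral route; on this read-out lower numbers stand for a weaker effect and higher numbers for a stronger effect at the one dose given:
- compound 1 `NC(=O)CC[C@H](NC(=O)CN(c1ncnc2c1ncn2C1CCCCO1)C1CC1)C(=O)OCc1ccccc1`: 39.4%
- compound 2 `C[C@H](NC(=O)CN(c1nc(Cl)nc2[nH]cnc12)C1CC1)C(=O)OCc1ccccc1`: 64.3%
- compound 3 `O=C(CN(c1nc(Cl)nc2[nH]cnc12)C1CC1)N[C@@H](CO)C(=O)O`: 39.8%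

Compound 1 carries the lowest of the three numbers, but compound 3 sits within the usual scatter of it, so the two cannot be told apart. Compound 2 alone stands clearly higher, beyond the scatter. No pair among these three differs in one place only, so no measured step is available to lean on.

Compound 4 `O=C(CN(c1ncnc2c1ncn2C1CCCCO1)C1CC1)N[C@@H](CCC(=O)OCc1ccccc1)C(=O)OCc1ccccc1` is the one not yet run. It differs from compound 1 as follows: benzyloxy in place of amino on a carbonyl carbon. The shared core and the cyclopropyl-bearing nitrogen are untouched; only the carbonyl carbon on the saturated chain changes its partner.

Among the measured compounds shown here, with no comparable step among the measured compounds, the direction of this change in this assay is open. The expected step from compound 1 to compound 4 is a number 4.6 percentage points higher from compound 1 to compound 4 (within the scatter), that is, no clear movement beyond the scatter. Compound 4 is estimated at 44%, with a range from 24% to 64%.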

Compound 4, a percentage reported as activity, at one dose (the size of the read-out at that dose, not a potency): 34.7%
Compound 4: middle estimate off by 9.3 percentage points, on the high side, within the range that was stated.
By their numbers in this assay, from the lowest: compounds 4, 1 and 3 (each within the scatter of the next); then compound 2.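

In this assay the series now has its first step in one place, benzyloxy in place of amino on a carbonyl carbon, and that step is a number 4.7 percentage points lower from compound 1 to compound 4 (within the scatter) and does not separate the two compounds. At this place on the saturated chain, then, carbamoyl and benzyloxycarbonyl cannot be told apart at the one dose and time given, even though the entering group brings a six-membered aromatic ring and the amide hydrogens leave. Nothing at hand accounts for this outcome.

Going by these compounds, whether a carboxylic acid or a small alkyl ester on the same carbonyl carbon would move the number beyond the scatter stays open. So does whether a longer or shorter chain carrying the carbamoyl group would give a different reading on the shared core.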